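Methoxy in Place of Dimethylamino on the Arylidene Ring

The source may hold more compounds than are shown below. What is called first, only, known or untested is meant among the compounds shown, and "the series" means these compounds.

Compound 1, `CCCCCC/C=C1\S/C(=N\c2csc(-c3ccc(Cl)cc3)c2)NC1=O`: "not determined" (no result reported)
Compound 2, `O=C1N/C(=N/c2csc(-c3ccc(Cl)cc3)c2)S/C1=C\c1ccc(F)cc1`: 8700 nM
Compound 3, `CN(C)c1ccc(/C=C2\S/C(=N\c3nc(-c4ccc(Cl)cc4)cs3)NC2=O)cc1`: 200 nM

In a functional assay on SW-620 cells (Homo sapiens) for cytotoxicity, read by MTT assay, with a stated time of 72 h (on this read-out lower numbers stand for stronger inhibition and higher numbers for weaker inhibition), compound 3 gives the lowest number of the two that were measured; compound 2 gives a far higher number, a gap beyond the scatter, and compound 1 has no result. Compound 4, `COc1ccc(/C=C2\S/C(=N\c3nc(-c4ccc(Cl)cc4)cs3)NC2=O)cc1`, differs from compound 3 in one place: methoxy in place of dimethylamino on an aromatic carbon. Among the compounds with values here, no measured pair shows this exact change, so its size is uncertain. The step of a 7.5-fold higher number from compound 3 to compound 4 (0.88 log units; beyond the scatter) is expected to go toward a higher number, beyond the scatter. Compound 2, carrying a different group at this place, gives 8700 nM and marks the likely upper side. For compound 4 the estimate is 1500 nM, within 300 nM to 8000 nM.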

Compound 4, half-maximal inhibitory concentration: 50 nM
Estimate against measurement, compound 4: 30-fold (1.48 log units) above; the whole stated range lies above it.
By their numbers in this assay, from the lowest: compound 4; then compound 3; then compound 2.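

In this assay, replacing dimethylamino with methoxy on the six-membered aromatic ring gives a 4.0-fold lower number from compound 3 to compound 4 (0.60 log units; beyond the scatter). Within the data shown here, this is the first measured pair that differs in one place, and it shows that this position responds to the group it carries and that dimethylamino is not needed for a low number. Nothing measured here explains the difference.

On these data alone, whether hydroxyl or a longer group such as ethoxy would give a lower or higher number remains open. So does whether this change would have the same effect on the core of compound 2.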